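From compound 2 to compound 3: a phenyl replaced

A few compounds are considered here, and "the series" means these few. Any claim that something is new, unique, unknown or untested is made for them only; others in the source may bear on it.

Measured in an ADME assay on Vero cells (Chlorocebus sabaeus) for cytotoxicity, read by crystal violet staining; a higher number here means that more compound is tolerated, a lower number that less compound is tolerated:
Compound 1 `CN(C)CCCN(/N=N/c1cc(F)ccc1F)c1ccccc1`: 7000 nM
Compound 2 `CN(C)CCCN(/N=N/c1ccccc1)c1cccc(C(F)(F)F)c1`: 20000 nM

Of these two compounds, compound 2 has the higher number at 20000 nM, and its gap to compound 1 lies beyond the usual scatter. Compound 3 `CN(C)CCCN(/N=N/c1cc(F)ccc1F)c1cccc(C(F)(F)F)c1` departs from compound 2 in one place, with 2,5-difluorophenyl in place of phenyl on a double-bonded nitrogen. Going by the values given here, no measured pair shows this change on its own, so the expectation rests on only two values. A lower number is expected in this assay because compound 1 gives 7000 nM with 2,5-difluorophenyl at that place. Compound 3 also keeps the trifluoromethyl group of compound 2, so a value close to that of compound 1 is expected rather than a further fall. The expected change is moderate, near the edge of the scatter, and is estimated as a 2.2-fold lower number from compound 2 to compound 3 (0.35 log units; beyond the scatter). The estimate for compound 3 is 9000 nM, with an expected range of 3500 nM to 20000 nM.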

Compound 3, half-maximal cytotoxic concentration: 30000 nM
Estimate against measurement, compound 3: 3.3-fold (0.52 log units) below; the whole stated range lies below it.
By their numbers in this assay, from the lowest: compound 1; then compounds 2 and 3 (each within the scatter of the next).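

In this assay, 2,5-difluorophenyl in place of phenyl on a double-bonded nitrogen gives a 1.5-fold higher number from compound 2 to compound 3 (0.18 log units; within the scatter), so with trifluoromethyl present on the other aryl group, this replacement cannot be told apart from repeat-measurement noise. Going by these compounds alone, the new compound also gives the first single-place reading of trifluoromethyl in place of hydrogen on an aromatic carbon: with 2,5-difluorophenyl held constant, the change gives a 4.3-fold higher number from compound 1 to compound 3 (0.63 log units; beyond the scatter), and more compound is tolerated with trifluoromethyl in this one pair. No measurement shown gives a reason for either step.

The compounds shown leave open whether the fluorine-bearing replacement would read the same without trifluoromethyl, and whether the trifluoromethyl step would hold with plain phenyl on the double-bonded nitrogen, so the two steps cannot be taken as general or as independent of each other. From the compounds shown here alone, it is also open how a nitrile or a carboxylic acid would read in place of trifluoromethyl, and how a longer chain or a morpholine at the end of the shared chain would read in this assay.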